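Stereochemistry of a cyclopentyl amide GCN2 inhibitor

The source may hold more compounds than are shown below. What is called first, only, known or untested is meant among the compounds shown, and "the series" means these compounds.

Compound 1 `COCCNC(=O)CNc1ncc2c(Br)nn(-c3ccc4ncccc4c3)c2n1`: "nd" (no result reported)
Compound 2 `COCCNC(=O)[C@H]1CC[C@@H](Nc2ncc3c(Br)nn(-c4ccc5ncccc5c4)c3n2)C1`: 156 nM
Compound 3 `COCCNC(=O)[C@@H]1CC[C@H](Nc2ncc3c(Br)nn(-c4ccc5ncccc5c4)c3n2)C1`: "nd" (no result reported)

Three compounds that share one core have been examined in an assay on SK-OV-3 cells for inhibition of eIF-2-alpha kinase GCN2 (Homo sapiens); a lower number here means a stronger inhibitor, a higher number a weaker inhibitor. Compound 1 carries an open-chain glycinamide linker and shows no result in this assay. Compound 2 closes that linker into a cyclopentane ring and in this assay compound 2 gives 156 nM. Compound 3 has no result in this assay, so compound 3 stands without a number; the only relation known for it is the fact that compounds 2 and 3 differ only in the configuration as drawn, which makes compound 3 the mirror image of compound 2.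

The unmeasured compound 4 `COCCNC(=O)[C@H]1CC[C@H](Nc2ncc3c(Br)nn(-c4ccc5ncccc5c4)c3n2)C1` follows from compound 3 by the two compounds have the same atoms and bonds and differ only in configuration as drawn: 1 of 2 stereo elements differ; a stereocentre at a saturated ring carbon is drawn R in compound 3 and S in compound 4. Compound 4 therefore shares one stereocentre as drawn with compound 2 and the other with compound 3, so it is a diastereomer of both. Within the data shown here, no measured pair in this set separates the two ring stereocentres, and no step between measured compounds exists, so the size and direction of the change from compound 3 to compound 4 cannot be read from the data.

For compound 4 the estimate is expected to be 300 nM, with a range from 60 nM to 3000 nM.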

Compound 4, half-maximal inhibitory concentration: 183 nM
The estimate for compound 4 lay 1.6-fold (0.21 log units) above the measured number; low and high end bracket the measured number.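

In this assay the set now holds its first readable comparison, a 1.2-fold higher number from compound 2 to compound 4 (0.07 log units; within the scatter). Inverting one stereocentre at a saturated ring carbon, with all atoms and bonds unchanged, therefore leaves the number within the scatter, so this one centre as drawn does not separate compound 2 from compound 4 in this assay. This reading rests on a single pair, and the only change within it is one of configuration: the fact that compounds 2 and 4 differ only in the configuration as drawn

On these data alone, compound 1 and compound 3 have no result, so steps involving either of them cannot be read, and the effect of the other ring stereocentre, or of inverting both together, remains unknown. The compounds shown also leave open whether the same indifference to configuration would hold with a carboxylic acid or a longer chain in place of the methoxyethyl chain, or with chlorine in place of bromine on the shared core.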